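Replacing cyclopropyl with methoxymethyl: compound 1 to compound 3

This account rests on a few compounds, and the source may have more. Where it says the series, first, only, none or still open, it means among the compounds named here.

- compound 1 `CC1=C(C(=O)OCc2ccccc2)C(c2ccc(Cl)cc2Cl)NC(=O)N1CCCC(=O)OCC1CC1`: > 100000 nM (a limit)
- compound 2 `COC(=O)CCCN1C(=O)NC(c2ccc(Cl)cc2Cl)C(C(=O)OCc2ccccc2)=C1C`: > 300000 nM (a limit)

In an ADME assay on MCF7 cells (Homo sapiens) for cytotoxicity, read by CellTiter-Glo, with a stated time of 24 h (a higher number here means a weaker inhibitor of growth, a lower number a stronger inhibitor of growth), compound 1 gives > 100000 nM, which is a limit and not a number. Compound 2 gives > 300000 nM, also a limit. Within the data shown here, the only measured step at this place, a step that the two limits leave unreadable from compound 1 to compound 2, therefore has no readable size. Compound 3 `COCCOC(=O)CCCN1C(=O)NC(c2ccc(Cl)cc2Cl)C(C(=O)OCc2ccccc2)=C1C` keeps the shared core of compound 1 and changes one group: methoxymethyl in place of cyclopropyl on a saturated chain carbon bound to an oxygen next to a carbonyl group. Among the measured compounds shown here, with a step that the two limits leave unreadable from compound 1 to compound 2 as the only guide, no step beyond the scatter is expected, and no direction can be favoured. The expected step is a step that the limit leaves unreadable from compound 1 to compound 3. Compound 3 is estimated at 150000 nM, with an expected range from 60000 nM to 300000 nM.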

Compound 3, concentration for 50% growth inhibition: > 100000 nM
Compound 3 gave a limit, no number; the forecaster's own chance of this, stated with the estimate: 85%; the middle value is on the limit's open side.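

Among these compounds, compound 3, like compound 1 and compound 2, gives only a limit, and no step among the three can be read. Going by these compounds, how cyclopropyl, methoxymethyl and hydrogen compare at this place stays open.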